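Notes on a small series sitting at the assay limit

The source may hold more compounds than are shown below. What is called first, only, known or untested is meant among the compounds shown, and "the series" means these compounds.

Measured so far, in an assay on HEK293 cells for binding affinity to 11-beta-hydroxysteroid dehydrogenase type 2 (Homo sapiens), read by scintillation proximity assay; a lower number here means a stronger inhibitor, a higher number a weaker inhibitor:
- compound 1 `CCCC1(C)SC(NC2CCCCCCC2)=NC1=O`; compound 1 gives > 10000 nM, a limit of the assay.
- compound 2 `CCCC1(C)SC(NC2CCCCCC2)=NC1=O`; compound 2 gives > 10000 nM, a limit of the assay.
- compound 3 `CCC1(C)SC(NC2CCCCCCC2)=NC1=O`; compound 3 gives > 10000 nM, a limit of the assay.

Compound 3 differs from compound 1 by hydrogen in place of methyl on a saturated chain carbon, two bonds along the chain from a saturated ring carbon. The step that the two limits leave unreadable from compound 1 to compound 3 cannot be sized because the limit of > 10000 nM in this assay, at which 3 of the 3 values shown sit, is where both values sit. The difference between the cores of compound 1 and compound 2 is not broken down here.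

Not yet measured is compound 4 `CCC1(C)SC(NC2CCCCCC2)=NC1=O`, which differs from compound 2 by hydrogen in place of methyl on a saturated chain carbon, two bonds along the chain from a saturated ring carbon, the same change as from compound 1 to compound 3. The step that the limit leaves unreadable from compound 2 to compound 4 is expected to be small. This rests on compound 1 and compound 3 both sitting at the limit of > 10000 nM in this assay, at which 3 of the 3 values shown sit, so the same change is not expected to bring compound 4 into the readable range. Compound 4 is estimated at 15000 nM, between 7000 nM and 50000 nM, most probably reported again only as a limit.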

Compound 4, half-maximal inhibitory concentration: > 10000 nM
Compound 4 ended at the assay's limit; the forecaster's own chance of this, stated with the estimate: 85%; the middle value is on the limit's open side.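

The step between compound 2 and compound 4 cannot be read, as both values are limits: the limit of > 10000 nM in this assay, at which 4 of the 4 values shown sit.

The compounds shown leave open whether any change to this series gives a readable value in this assay.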